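The compounds below may be only part of what the source reports. "The series", "measured", "known", "first", "only" and "open" are said of these compounds alone.

Measured compounds:
- compound 1 `CCN(Cc1ccccc1)C(=O)C1CCN(S(=O)(=O)c2ccc(OC)cc2)CC1` — in a functional assay on CHO cells for positive allosteric modulation of muscarinic acetylcholine receptor M5 (Homo sapiens), read by calcium flux (on this read-out lower numbers stand for an effect already at smaller amounts and higher numbers for an effect only at larger amounts of compound), compound 1 gives 3310 nM; 3300 nM (2 entries)
- compound 2 `CCN(Cc1ccccc1)C(=O)C1CCN(S(=O)(=O)c2ccccc2OC)CC1` — in this assay compound 2 reaches only the limit > 10000 nM

Compound 1 and compound 2 share one core and differ only in the methoxyphenyl attached to the sulfonyl sulfur. The repeated entries of compound 1 agree closely (the several entries of compound 1 in this assay, 3310 nM; 3300 nM (2 entries)). Compound 2 yields no number at all in this assay; its entry is a limit, not a measured value, and it stands among the values at that limit (the limit of > 10000 nM in this assay, at which 1 of the 2 values shown sits). Compound 2 thus sits at the weak end of everything shown here.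

Compound 3 `CCN(Cc1ccccc1)C(=O)C1CCN(S(=O)(=O)c2c[nH]cn2)CC1` is not yet measured. It differs from compound 2 by 1H-imidazol-4-yl in place of 2-methoxyphenyl on a sulfonyl sulfur. Among the measured compounds shown here, since no measured pair covers a change of this kind, the direction rests on compound 2 alone, which already gives only a limit. The step from compound 2 to compound 3 is expected to be small or none beyond the scatter, with a reading again likely to stop at the limit: a step that the limit leaves unreadable from compound 2 to compound 3. For compound 3 the expected value in this assay is 14000 nM, within a range from 4000 nM to 50000 nM.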

Compound 3, half-maximal effective concentration: > 10000 nM
Compound 3: a limit, no number; the forecaster's own chance of this, stated with the estimate: 70%; the middle value is on the limit's open side.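

Compound 2 and compound 3 each give only a limit in this assay, so the step between them cannot be read. The compounds shown leave open whether 1H-imidazol-4-yl in place of 2-methoxyphenyl on a sulfonyl sulfur changes the effect at all.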